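Benzothiophene in place of phenyl on the shared core

A few compounds are considered here, and "the series" means these few. Any claim that something is new, unique, unknown or untested is made for them only; others in the source may bear on it.

Compound 1 `CCOC(=O)c1cnc(-c2ccccc2)nc1NN1C(=O)C=C(C)C1=O` is one of three compounds with a measurement in a functional assay on Jurkat cells for inhibition of nuclear factor NF-kappa-B complex (Homo sapiens); on this read-out lower numbers stand for stronger inhibition and higher numbers for weaker inhibition. Compound 1 gives 100 nM, the second highest number of the three. Compound 2 `CCOC(=O)c1cnc(-c2cccs2)nc1NN1C(=O)C=C(C)C1=O` gives 20 nM, and compound 3 `CCOC(=O)c1cnc(-c2ccc(C(F)(F)F)cc2)nc1NN1C(=O)C=C(C)C1=O` gives 400 nM. Among the measured steps, the change a 5.0-fold lower number from compound 1 to compound 2 (0.70 log units; beyond the scatter) and the change a 4.0-fold higher number from compound 1 to compound 3 (0.60 log units; beyond the scatter), while a 20-fold higher number from compound 2 to compound 3 (1.30 log units; beyond the scatter).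

Compound 4 `CCOC(=O)c1cnc(-c2cc3ccccc3s2)nc1NN1C(=O)C=C(C)C1=O` differs from compound 1 in a single place: 1-benzothiophen-2-yl in place of phenyl on an aromatic carbon. The entering group carries the five-membered aromatic ring with one sulfur that also distinguishes compound 2, joined to a six-membered aromatic ring of carbon only. Among the compounds with values here, the step that bears on it most directly is the one from compound 1 to compound 2, which lowered the number well beyond the scatter; no measured compound carries the fused two-ring group itself, so the effect of the added ring is not known.

He therefore expects a lower number for compound 4, with the step of a 2.5-fold lower number from compound 1 to compound 4 (0.40 log units; beyond the scatter) held somewhat short of the gain seen in compound 2 with 20 nM, given the uncertainty. His estimate for compound 4 in this assay is 40 nM, within a range from 10 nM to 160 nM.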

Compound 4, half-maximal inhibitory concentration: 4000 nM
For compound 4 the middle estimate is 100-fold (2.00 log units) below the measured one; the measured number lies above the stated range.
By their numbers in this assay, from the lowest: compound 2; then compound 1; then compound 3; then compound 4.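

On the aromatic carbon between two ring nitrogen atoms, adding a fused ring to thiophen-2-yl does not keep its gain in this assay: the change gives a 200-fold higher number from compound 2 to compound 4 (2.30 log units; beyond the scatter) and, against phenyl, a 40-fold higher number from compound 1 to compound 4 (1.60 log units; beyond the scatter) in the opposite direction to the step that thiophen-2-yl gave. The fused group also falls behind 4-(trifluoromethyl)phenyl, with a 10-fold higher number from compound 3 to compound 4 (1.00 log units; beyond the scatter) as the step, so the five-membered aromatic ring with one sulfur does not by itself set the number, since compound 2 and compound 4 both carry it and stand at opposite ends of the four. No measured evidence here accounts for this reversal.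

The compounds shown do not tell whether the loss follows the fused ring itself or the sulfur within it, a question that a naphthalen-2-yl group, with carbon alone in both rings, would address. They also leave open whether the same order holds with a carboxylic acid in place of the ethoxycarbonyl group.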